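A few compounds are considered here, and "the series" means these few. Any claim that something is new, unique, unknown or untested is made for them only; others in the source may bear on it.

Measured so far:
- compound 1 `CCCCCCOc1cccc(O)c1C(=O)/C=C/c1ccc(O)cc1`: > 30000 nM
- compound 2 `CCCCCCCCCCCCCCCCCCOc1cccc(O)c1C(=O)/C=C/c1ccc(O)cc1`: > 30000 nM

In an ADME assay on RAW264.7 cells (Mus musculus) for cytotoxicity, read by MTT assay (on this read-out higher numbers stand for weaker inhibition and lower numbers for stronger inhibition), compound 1 gives > 30000 nM, which is a limit of the assay and not a number. Compound 2 gives > 30000 nM, which is likewise a limit. Among the compounds with values here, the only measured step is a step that the two limits leave unreadable from compound 1 to compound 2, so it offers no size to carry over. What the two compounds do share is the limit of > 30000 nM in this assay, at which 2 of the 2 values shown sit.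

Compound 3 `O=C(/C=C/c1ccc(O)cc1)c1c(O)cccc1OCc1ccccc1` has not yet been measured. It differs from compound 1 by phenyl in place of pentyl on a saturated chain carbon bound to an oxygen on an aromatic ring, which turns hexyloxy into benzyloxy. Because of the limit of > 30000 nM in this assay, at which 2 of the 2 values shown sit, no clear change is expected in this assay, in either direction, and another limit is quite likely. The expected step is a step that the limit leaves unreadable from compound 1 to compound 3. For compound 3 the estimate is 35000 nM, with an expected range from 12000 nM to 100000 nM.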

Compound 3, half-maximal inhibitory concentration: > 30000 nM
Compound 3 ended at the assay's limit (the forecaster's own chance of this, stated with the estimate: 75%); the middle value lies beyond the limit too.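

Within the data shown here, compound 1 and compound 3 both end at a limit in this assay and not at a number, so no step between them can be read: the limit of > 30000 nM in this assay, at which 3 of the 3 values shown sit. The compounds shown leave open how far each lies beyond that limit, and whether hexyloxy and benzyloxy differ in this read-out at all.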